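The source may report more compounds than this note shows. Statements on the series, on what has been measured and on what is new or still open speak of the compounds shown alone.

Working notes on the series. Compound 2 `COc1cccc(CNCc2c(-c3nnc(SC(C)C)n3-c3ccccc3)n(C)c3ccccc23)c1` gives 6.27 in a physicochemical assay for lipophilicity (a lower number here means a more polar compound, a higher number a more lipophilic compound), and stands highest of the three numbers: compound 3 `CC(C)Sc1nnc(-c2c(CN3CCC(N4CCCC4)CC3)c3ccccc3n2C)n1-c1ccccc1` gives 5.16 and compound 1 `CC(C)Sc1nnc(-c2c(CNCCN3CCCC3)c3cc(F)ccc3n2C)n1-c1ccccc1` gives 4.99, both beyond the scatter below compound 2. Compound 4 `CC1CCCN(Cc2c(-c3nnc(SC(C)C)n3-c3ccccc3)n(C)c3ccccc23)C1` has not yet been measured; its change from compound 2 is 3-methylpiperidin-1-yl in place of (3-methoxybenzyl)amino on a saturated chain carbon bound to an aromatic carbon. Among the compounds with values here, the only measured step at this position is a number 1.11 log units lower from compound 2 to compound 3 (beyond the scatter), a large drop in this assay where the group entering carried a second ring with a nitrogen. The group entering in compound 4 is smaller and carries a single nitrogen, so the drop is expected to be in the same direction but not as large; the pair of compound 1 and compound 2 differs in more than one place and is not a clean step. For compound 4 the estimated step is a number 0.47 log units lower from compound 2 to compound 4 (beyond the scatter). Compound 4 is therefore expected to give about 5.8 in this assay, most likely between 5.3 and 6.3.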

Compound 4, partition coefficient: 6.03
The estimate for compound 4 lay 0.23 log units below the measured number, within the range that was stated.
By their numbers in this assay, from the lowest: compounds 1 and 3 (each within the scatter of the next); then compounds 4 and 2 (each within the scatter of the next).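

In this assay, replacing the group on a saturated chain carbon bound to an aromatic carbon need not shift the number: a number 0.24 log units lower from compound 2 to compound 4 (within the scatter), even though 3-methylpiperidin-1-yl has fewer heavy atoms than (3-methoxybenzyl)amino and no hydrogen-bond donor. The large drop seen earlier therefore does not accompany every replacement of (3-methoxybenzyl)amino, and the contrast between the two ring-bearing amines is direct: a number 0.87 log units higher from compound 3 to compound 4 (beyond the scatter). No measurement on hand accounts for this contrast.

Still open is whether the methyl group of 3-methylpiperidin-1-yl contributes to the number, as plain piperidin-1-yl is not among the compounds shown. Also open, on these data alone, is how morpholin-4-yl or a carboxylic acid at this place would read.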